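The source may report more compounds than this note shows. Statements on the series, on what has been measured and on what is new or still open speak of the compounds shown alone.

Series notes. Three compounds share a five-membered aromatic ring with two nitrogens as core, with two aryl groups and either a 2,5-dihydroxyphenyl group or its quinone counterpart on the ring. Compound 1 `Oc1ccc(O)c(-c2cc(-c3ccc(Cl)cc3)nn2-c2ccccc2)c1` gives 33200 nM in a functional assay on cells (Cancer cell lines, Homo sapiens) for cytotoxicity, read by sulforhodamine B assay, with a stated time of 48 h; a higher number here means a weaker inhibitor of growth, a lower number a stronger inhibitor of growth. Compound 3 `O=C1C=CC(=O)C(c2cc(-c3ccc(Cl)cc3)nn2-c2ccccc2)=C1` gives 70100 nM. Compound 2 `CC(=O)NS(=O)(=O)c1ccc(-n2nc(-c3ccccc3)cc2-c2cc(O)ccc2O)cc1` gives 100000 nM; the difference between the cores of compound 2 and compound 1 is not broken down here, and what the two numbers show is that compound 2 stands higher.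

The change from compound 1 to compound 3 is a group of 8 heavy atoms (6 carbon, 2 oxygen; one six-membered non-aromatic ring of carbon only) in place of a group of 8 heavy atoms (6 carbon, 2 oxygen; one six-membered aromatic ring of carbon only), on an aromatic carbon, and it produced a 2.1-fold higher number from compound 1 to compound 3 (0.32 log units; beyond the scatter).

Compound 4 `CC(=O)NS(=O)(=O)c1ccc(-n2nc(-c3ccccc3)cc2C2=CC(=O)C=CC2=O)cc1` is not yet measured. It arises from compound 2 by a group of 8 heavy atoms (6 carbon, 2 oxygen; one six-membered non-aromatic ring of carbon only) in place of a group of 8 heavy atoms (6 carbon, 2 oxygen; one six-membered aromatic ring of carbon only), on an aromatic carbon, the same kind of change as from compound 1 to compound 3, but not the same: in compound 1 the place is next to the ring atom that bears a phenyl group and two ring bonds from the ring atom that bears a 4-chlorophenyl group, while in compound 2 the place is next to the ring atom that bears a large group and two ring bonds from the ring atom that bears a phenyl group.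

Compound 2 already sits at the top of the measured range with 100000 nM, so the expected step from compound 2 to compound 4 in this assay is estimated at a 1.5-fold higher number from compound 2 to compound 4 (0.18 log units; within the scatter), modelled on the earlier step. Compound 4 is expected to give about 150000 nM, with the range 70000 nM to 320000 nM.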

Compound 4, concentration for total growth inhibition: 100000 nM
Compound 4: the middle estimate sits 1.5-fold (0.18 log units) above what was measured; measured number inside the range.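

In this assay, putting the quinone ring in place of the 2,5-dihydroxyphenyl group gives no change at the digits printed from compound 2 to compound 4 (within the scatter), while the same change on the core of compound 1 gives a 2.1-fold higher number from compound 1 to compound 3 (0.32 log units; beyond the scatter). The step is beyond the scatter on one core and within it on the other, yet the two steps cannot be told apart, so these data give no sign that the outcome of this change depends on the core: the same change on two cores in this assay, a 2.1-fold higher number (0.32 log units; beyond the scatter) from compound 1 to compound 3 and no change at the digits printed (within the scatter) from compound 2 to compound 4, 2.1-fold (0.32 log units) apart, within the scatter of two such steps. Within the data shown here, this does not show that the change behaves alike on every core, since it rests on one pair per core, and the two cores differ in more than one place, so no difference between the steps could be traced to a single group in any case.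

The compounds shown leave open how the change reads on a core that differs from compound 1 or compound 2 in one place only, such as one carrying the 4-chlorophenyl group together with the large group of compound 2. Also open, on these data alone, is whether it holds with a carboxylic acid or an amine on the ring at the nitrogen, or with a methoxy group in place of one hydroxyl of the 2,5-dihydroxyphenyl group.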